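Extending the aryl substituent from methyl to butyl

A few compounds are considered here, and "the series" means these few. Any claim that something is new, unique, unknown or untested is made for them only; others in the source may bear on it.

Compound 1 `CCCCc1ccc(-c2cc(N3CCC(CNS(N)(=O)=O)CC3)ncn2)cc1` — 15200 nM
Compound 2 `Cc1ccc(-c2cc(N3CCC(CCNS(N)(=O)=O)CC3)ncn2)cc1` — 52300 nM

In a functional assay on HT-29 cells (Homo sapiens) for antiproliferative activity, read by sulforhodamine B assay, with a stated time of 48 h (on this read-out lower numbers stand for stronger inhibition of growth and higher numbers for weaker inhibition of growth), compound 2 gives the higher of the two numbers; compound 1 sits at a lower number, a gap beyond the usual scatter, though compound 1 differs from compound 2 in more than one place. Compound 3 `CCCCc1ccc(-c2cc(N3CCC(CCNS(N)(=O)=O)CC3)ncn2)cc1` differs from compound 2 by propyl in place of hydrogen on a saturated chain carbon bound to an aromatic carbon. Among the measured compounds shown here, no single-change step is known here, so the expected step of a 2.4-fold lower number from compound 2 to compound 3 (0.38 log units; beyond the scatter) rests on the resemblance of compound 3 to compound 1 in its butyl group. Compound 3 is estimated at 22000 nM, within 8000 nM to 60000 nM.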

Compound 3, concentration for 50% growth inhibition: 13300 nM
Beside the measured number, compound 3's estimate is 1.7-fold (0.22 log units) above it, within the range that was stated.
By their numbers in this assay, from the lowest: compounds 3 and 1 (each within the scatter of the next); then compound 2.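

Changing methyl to butyl with everything else in the core of compound 2 kept the same gives a 3.9-fold lower number from compound 2 to compound 3 (0.59 log units; beyond the scatter) in this assay, so this change alone moves the number. With butyl in place, swapping sulfamoylamino for (sulfamoylamino)methyl on a saturated chain carbon bound to a saturated ring carbon gives a 1.1-fold lower number from compound 1 to compound 3 (0.06 log units; within the scatter) and makes no readable difference. Nothing available explains either result. Still open, from the compounds shown here alone, is whether a chain longer than butyl would lower the number further. An amine or a carboxylic acid at the end of that chain is also untested in the compounds shown.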